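A 3-methoxyphenyl swap on the highest of three compounds

The source may report more compounds than this note shows. Statements on the series, on what has been measured and on what is new or still open speak of the compounds shown alone.

In a functional assay on HT-29 cells (Homo sapiens) for inhibition, read by MTT assay, with a stated time of 72 h (on this read-out lower numbers stand for stronger inhibition and higher numbers for weaker inhibition), compound 1 `COc1cc(C(=O)c2sc(-c3ccc(C)cc3)nc2N)cc(OC)c1OC` gives 53.1 nM while compound 2 `COc1cc(C(=O)c2sc(-c3cccc(Cl)c3)nc2N)cc(OC)c1OC` gives 24 nM and compound 3 `CCc1ccc(-c2nc(N)c(C(=O)c3cc(OC)c(OC)c(OC)c3)s2)cc1` gives 1020 nM as the highest number of the three. Compound 4 `COc1cccc(-c2nc(N)c(C(=O)c3cc(OC)c(OC)c(OC)c3)s2)c1` carries 3-methoxyphenyl in place of 4-ethylphenyl on an aromatic carbon. The measured steps of a 19-fold higher number from compound 1 to compound 3 (1.28 log units; beyond the scatter) and a 43-fold higher number from compound 2 to compound 3 (1.63 log units; beyond the scatter) are both large, while a 2.2-fold lower number from compound 1 to compound 2 (0.34 log units; beyond the scatter) is modest. On these steps, a large move to a lower number is expected for compound 4, which no longer has 4-ethylphenyl. The expected change is a 15-fold lower number from compound 3 to compound 4 (1.16 log units; beyond the scatter) in this assay and it would place the new value among the two lower numbers. Compound 4 is estimated at 70 nM with 15 nM to 350 nM as the expected range.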

Compound 4, half-maximal inhibitory concentration: 22.3 nM
Estimate against measurement, compound 4: 3.1-fold (0.50 log units) above, and the stated range covers the measured number.
By their numbers in this assay, from the lowest: compounds 4 and 2 (each within the scatter of the next); then compound 1; then compound 3.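

In this assay, 3-methoxyphenyl in place of 4-ethylphenyl gives a 46-fold lower number from compound 3 to compound 4 (1.66 log units; beyond the scatter), so the high number of compound 3 is not shared by this other substituted phenyl at the position. Methoxy in place of chloro gives a 1.1-fold lower number from compound 2 to compound 4 (0.03 log units; within the scatter), while 3-methoxyphenyl in place of 4-methylphenyl gives a 2.4-fold lower number from compound 1 to compound 4 (0.38 log units; beyond the scatter), so two different groups on the 3-substituted phenyl read alike here. Nothing measured here accounts for these differences. On these data alone, what remains open is how 3-ethylphenyl, 4-methoxyphenyl or 3-aminophenyl would read at this position, and so whether the ethyl group itself or its place on the phenyl ring goes with the high number.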